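The source may report more compounds than this note shows. Statements on the series, on what has been measured and on what is new or still open speak of the compounds shown alone.

Measured in a functional assay on RAW264.7 cells (Mus musculus) for inhibition, read by Griess assay, with stated times of 1 h and 24 h; on this read-out higher numbers stand for weaker inhibition and lower numbers for stronger inhibition:
- Compound 1 `COc1ccc(C(O)C2OC(=O)c3c(OC)cc(OC)cc32)cc1`: > 10000 nM
- Compound 2 `CCC(C)Oc1ccc(C(O)C2OC(=O)c3c(OC)cc(OC)cc32)cc1`: > 10000 nM

Both values are limits, not numbers, and compound 2 shares (the limit of > 10000 nM in this assay, at which 2 of the 2 values shown sit). Compound 3 `COc1cc(OC)c2c(c1)C(C(O)c1ccc(OCc3ccc(F)cc3)cc1)OC2=O` changes one group of compound 2: 4-fluorobenzyl in place of sec-butyl on an oxygen on an aromatic ring. Among the measured compounds shown here, the only measured step at this oxygen is a step that the two limits leave unreadable from compound 1 to compound 2, where sec-butyl replaced methyl, so it offers no size to carry over. With no size to go on, little change is expected, and any readable shift could only be toward stronger inhibition. The expected step is a number no higher from compound 2 to compound 3 (the limit leaves the size open). For compound 3 the estimate is 10000 nM, with an expected range from 3000 nM to 30000 nM.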

Compound 3, half-maximal inhibitory concentration: 760 nM
Estimate against measurement, compound 3: 13-fold (1.12 log units) above, and the stated range ends above it.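

In this assay, this oxygen on an aromatic ring now gives a readable result: 4-fluorobenzyl in place of sec-butyl produces an at least 13-fold lower number from compound 2 to compound 3 (1.11 log units; beyond the scatter), and the comparison with the methyl group of compound 1 produces an at least 13-fold lower number from compound 1 to compound 3 (1.11 log units; beyond the scatter). The step between the two earlier compounds cannot be read, as each sits at a limit of the assay and not at a number: the limit of > 10000 nM in this assay, at which 2 of the 3 values shown sit.

Still open, as far as these compounds go, is whether the six-membered aromatic ring or the fluorine carries the change. A plain benzyl group would separate the two.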